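Ethyl on the Ring Nitrogen of Compound 1

This account rests on a few compounds, and the source may have more. Where it says the series, first, only, none or still open, it means among the compounds named here.

Compound 1 `Cc1nc2c(OCc3ccccc3)cccn2c1N` is the starting point. In a functional assay on the whole organism with Canis familiaris (Canis lupus familiaris) as the target, at a dose of 8 mg/kg by the oral route (on this read-out higher numbers stand for a stronger effect at the one dose given and lower numbers for a weaker effect), compound 1 gives 96%, the highest of the three measured numbers. Compound 2 `Cc1nc2c(OCc3ccc(C(F)(F)F)cc3)cccn2c1N` gives 8%, and compound 3 `Cc1nc2c(OCc3ccccn3)cccn2c1N` gives 15%. Both measured steps, a number 88 percentage points lower from compound 1 to compound 2 (beyond the scatter) and a number 81 percentage points lower from compound 1 to compound 3 (beyond the scatter), concern the benzyl ether side of the molecule and are large. Compound 4 `CCNc1c(C)nc2c(OCc3ccccc3)cccn12` differs from compound 1 elsewhere: ethyl in place of hydrogen on a nitrogen on an aromatic ring, that is, amino to ethylamino. Among the compounds with values here, no measured step touches this nitrogen, so neither step bears directly on the change. The large effects of the other steps only show that this read-out can move strongly. For compound 4 a moderate fall is expected, a number 26 percentage points lower from compound 1 to compound 4 (beyond the scatter), giving an estimated 70% with a range from 25% to 98%.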

Compound 4, a percentage reported as inhibition, in the whole organism at one dose (the size of the read-out at that dose, not a potency): 68%
Beside the measured number, compound 4's estimate is 2 percentage points above it, and the stated range covers the measured number.
By their numbers in this assay, from the lowest: compounds 2 and 3 (each within the scatter of the next); then compound 4; then compound 1.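

Ethyl in place of hydrogen on this nitrogen gives a number 28 percentage points lower from compound 1 to compound 4 (beyond the scatter), the first measured change at this position. In this assay, compound 4 still gives 68%, so this amino hydrogen can be replaced with the effect reduced but not lost. Nothing available explains why the number falls.

The compounds shown leave open how methyl, a longer chain such as propyl, or acetyl on this nitrogen would read. They also leave open whether a second ethyl there would lower the number further.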